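Fluoro for methyl on the shared core of compound 1

The compounds below may be only part of what the source reports. "The series", "measured", "known", "first", "only" and "open" are said of these compounds alone.

Going by the values given here, compound 1 `CSc1ccc(C)cc1NCC1=NCCN1` is the only member of this set with a number rather than a limit in an assay on CHO cells for binding affinity to Alpha-2C adrenergic receptor (Homo sapiens), read by radioligand binding (on this read-out lower numbers stand for stronger inhibition and higher numbers for weaker inhibition), where compound 1 gives 200 nM. Compound 2 `Cc1ccc(S(C)(=O)=O)c(NCC2=NCCN2)c1` carries methylsulfonyl in place of methylsulfanyl on an aromatic carbon, and in this assay compound 2 reaches only a limit, < 5020 nM. Compound 3 `CS(=O)(=O)c1cc(F)ccc1NCC1=NCCN1` likewise reaches only a limit in this assay, < 5020 nM. The step that the limit leaves unreadable from compound 1 to compound 2 is therefore of unreadable size, and the limit of < 5020 nM in this assay, at which 2 of the 3 values shown sit, is the reason the comparison stays open.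

Compound 4 `CSc1ccc(F)cc1NCC1=NCCN1` keeps the methylsulfanyl group of compound 1 and differs from it by a single exchange: fluoro in place of methyl on an aromatic carbon, para to a methylsulfanyl group. Among the compounds with values here, no measured step in this assay touches that exchange; the one measured step concerns the methylsulfanyl group itself and cannot be read. With nothing to suggest a shift in either direction, a change no larger than the usual scatter is expected, so that compound 4 is estimated to lie close to compound 1, with the step of a 1.3-fold higher number from compound 1 to compound 4 (0.10 log units; within the scatter) expected to be small. Compound 4 is thus expected to give about 250 nM in this assay, within a range from 80 nM to 800 nM.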

Compound 4, inhibition constant: 115 nM
Estimate against measurement, compound 4: 2.2-fold (0.34 log units) above; measured number inside the range.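

In this assay, the position para to a methylsulfanyl group now has a readable exchange, fluoro in place of methyl on an aromatic carbon, which gives a 1.7-fold lower number from compound 1 to compound 4 (0.24 log units; within the scatter). Between these two compounds, then, the exchange of methyl for fluoro at this position produces no difference beyond the scatter, and the methylsulfanyl group is kept on both sides of the comparison. Going by these compounds alone, the earlier compounds could not show this, as their one step concerned the methylsulfanyl group itself and cannot be read, and compound 4 now joins compound 1 as a second member of the set with a number rather than a limit, though this rests on a single pair.

Compound 3 carries the same fluoro with methylsulfonyl in place of methylsulfanyl but gives only a limit, < 5020 nM, so what the methylsulfonyl group does to the number stays unreadable with either fluoro or methyl at this position: the limit of < 5020 nM in this assay, at which 2 of the 4 values shown sit. How this position responds to anything other than methyl or fluoro, such as an amine, a carboxylic acid or a longer chain, remains open in the compounds shown.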